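Mirror-image partners on a tetrabromobenzotriazole core

The source may hold more compounds than are shown below. What is called first, only, known or untested is meant among the compounds shown, and "the series" means these compounds.

In a functional assay on MCF7 cells (Homo sapiens) for antiproliferative activity, read by MTT assay, with a stated time of 24 h, tested at 100 uM (a lower number here means a stronger effect, a higher number a weaker effect of the compound at the concentration tested), two compounds have been measured so far:

Compound 1, `C[C@@H](O)CCn1nc2c(Br)c(Br)c(Br)c(Br)c2n1`, gives 18%.
Compound 2, `OC(CCn1nc2c(Br)c(Br)c(Br)c(Br)c2n1)c1ccccc1`, gives 13%.

Compound 1 holds the highest of the two numbers, which here means the weaker effect at the concentration tested, but its nearest neighbour, compound 2, sits only within the usual scatter of it, so the two cannot be told apart on these data. Both share the same brominated core; they differ only in the side chain carrying the hydroxyl group.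

Compound 3, `C[C@H](O)CCn1nc2c(Br)c(Br)c(Br)c(Br)c2n1`, has not yet been measured. Compared with compound 1, (the two compounds have the same atoms and bonds and differ only in configuration as drawn: 1 of 1 stereo elements differ; a stereocentre at a saturated chain carbon is drawn R in compound 1 and S in compound 3). Nothing is added and nothing is removed; the chain is the same and only the drawn configuration at its stereocentre is flipped.

Within the data shown here, no step between two measured compounds that differ in one place is available to guide this change, and the two measured numbers lie within scatter of each other. With nothing pointing to a direction, the expected step of no change at the digits printed from compound 1 to compound 3 (within the scatter) in this assay is none beyond the scatter. Compound 3 is therefore estimated to give about 18%, within a range from 8% to 30%.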

Compound 3, a percentage reported as activity, at one concentration (the size of the read-out at that concentration, not a potency): 31%
Compound 3: middle estimate off by 13 percentage points, on the low side; measured number above the stated range.
By their numbers in this assay, from the lowest: compounds 2 and 1 (each within the scatter of the next); then compound 3.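

In this assay, flipping the stereocentre at the saturated chain carbon from R to S gives a number 13 percentage points higher from compound 1 to compound 3 (beyond the scatter), and since a higher number here means a weaker effect, the S form is the weaker of this mirror-image pair. Among these compounds, the earlier compounds could not show this, as the only comparison available was between two different side chains whose numbers could not be told apart; this pair shows that the drawn configuration at this one carbon can matter on its own, even with no atom added or removed. The gap can be assigned to that configuration alone because nothing else separates the pair: the fact that compounds 1 and 3 differ only in the configuration as drawn.

This is a single pair at a single concentration, so it does not show why the R form is the stronger one, or whether the same flip would matter with the phenyl group of compound 2, which has no configuration drawn at its carbon. Also open, from the compounds shown here alone, is whether the preference would survive with an amine in place of the hydroxyl group, or with a longer chain between the core and the stereocentre.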